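The source may hold more compounds than are shown below. What is called first, only, known or untested is meant among the compounds shown, and "the series" means these compounds.

Measured in a functional assay (aorta) for inhibition, with Rattus norvegicus as the target, with a stated time of 8 days; a higher number here means a weaker inhibitor, a lower number a stronger inhibitor:
- compound 1 `FC(F)(F)c1cccc(N2CCN(c3ccc(-c4ncns4)nn3)CC2)c1`: 70 nM
- compound 2 `CNc1nsc(-c2ccc(N3CCN(c4cccc(C(F)(F)F)c4)CC3)nn2)n1`: 3 nM
- compound 3 `Cc1nsc(-c2ccc(N3CCN(c4cccc(C(F)(F)F)c4)CC3)nn2)n1`: 0.3 nM

Compound 1 has the highest number of the three and is the weakest inhibitor in the set, at 70 nM. The unmeasured compound 4 `FC(F)(F)c1cc(N2CCN(c3ccc(-c4ncns4)nn3)CC2)cc(C(F)(F)F)c1` differs from it by trifluoromethyl in place of hydrogen on an aromatic carbon. This is trifluoromethyl in place of hydrogen on an aromatic carbon of a six-membered aromatic ring of carbon only, meta to a large group and meta to a trifluoromethyl group.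

Two measured steps start from compound 1, and both are large: a 23-fold lower number from compound 1 to compound 2 (1.37 log units; beyond the scatter) and a 230-fold lower number from compound 1 to compound 3 (2.37 log units; beyond the scatter). A third, a 10-fold lower number from compound 2 to compound 3 (1.00 log units; beyond the scatter), is modest. All three changes lie outside the six-membered aromatic ring of carbon only, so none of them tests the new substitution directly. They show only that a single replacement on compound 1 can move the number far in this assay. The series holds no measured change on the ring that carries the trifluoromethyl group, so no direction is supported. The expected result is no shift beyond the scatter, with wide uncertainty on both sides: no change at the digits printed from compound 1 to compound 4 (within the scatter). For compound 4 the estimated value is 70 nM, with an expected range from 12 nM to 400 nM.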

Compound 4, half-maximal inhibitory concentration: < 1 nM
Compound 4 ended at the assay's limit; the forecaster's own chance of this, stated with the estimate: 3%; middle value at least 70-fold (1.84 log units) from the limit.
By their numbers in this assay, from the lowest: compound 3; then compound 2; then compound 1.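

Going by these compounds alone, the ring carrying the trifluoromethyl group is not a silent position: in this assay, a second trifluoromethyl group in place of hydrogen on that ring gives an at least 70-fold lower number from compound 1 to compound 4 (1.84 log units; beyond the scatter), the first measured change on this ring. Compound 4 stands at a limit of the assay and not at a number: the limit of < 1 nM in this assay, at which 1 of the 4 values shown sits. The size of this step therefore remains bounded on one side only, but compound 1 now responds strongly both to this change on the six-membered aromatic ring of carbon only and to a change outside it, as a 230-fold lower number from compound 1 to compound 3 (2.37 log units; beyond the scatter) shows.

On these data alone, it remains open whether the step belongs to trifluoromethyl specifically, or whether a chlorine, a methoxy group or an amine at the same place on the ring would move the number in the same direction in this assay. Also open, as far as these compounds go, are how far the true value of compound 4 lies past its limit and whether this second trifluoromethyl group, combined with the methyl group of compound 3, would give any further movement.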